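The source may hold more compounds than are shown below. What is called first, only, known or untested is meant among the compounds shown, and "the series" means these compounds.

Compound 1 `O=c1[nH]cnc2c1c(-c1cccs1)cn2[C@@H]1O[C@H](CO)[C@@H](O)[C@H]1O` opens the account. In a functional assay on CEM-DNR-bulk cells (Homo sapiens), read by MTT assay, with a stated time of 72 h (on this read-out higher numbers stand for weaker inhibition and lower numbers for stronger inhibition), compound 1 gives > 20000 nM, which is a limit of the assay rather than a number. Compound 2 `Nc1nc2c(c(-c3cccs3)cn2[C@@H]2O[C@H](CO)[C@@H](O)[C@H]2O)c(=O)[nH]1` gives > 20000 nM in this assay, likewise a limit. Compound 3 `C#Cc1cn([C@@H]2O[C@H](CO)[C@@H](O)[C@H]2O)c2nc(N)nc(OC)c12` gives > 20000 nM in this assay, again a limit. Where compound 1 stands against the others therefore cannot be read, and the only step between measured compounds, a step that the two limits leave unreadable from compound 1 to compound 2, stays unreadable, as the limit of > 20000 nM in this assay, at which 3 of the 3 values shown sit, shows. Compound 4 `O=c1[nH]cnc2c1c(-c1ccccc1)cn2[C@@H]1O[C@H](CO)[C@@H](O)[C@H]1O` differs from compound 1 by phenyl in place of thiophen-2-yl on an aromatic carbon. Among the compounds with values here, no measured step bears on this change, so the step that the limit leaves unreadable from compound 1 to compound 4 is expected to stay within the scatter. For compound 4 in this assay the expected value is estimated at 30000 nM, with an estimated range from 10000 nM to 100000 nM, most probably reported once more as a limit.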

Compound 4, half-maximal inhibitory concentration: > 20000 nM
Compound 4: a limit, no number; the forecaster's own chance of this, stated with the estimate: 85%; the middle value lies beyond the limit too.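

In this assay compound 4 gives > 20000 nM, a limit and not a number, so no new step can be read against compound 1. The compounds shown leave open how far any change on the shared core moves the value: the limit of > 20000 nM in this assay, at which 4 of the 4 values shown sit.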